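Difluoromethoxy for Methoxy on the Sulfonamide Aryl Group

A few compounds are considered here, and "the series" means these few. Any claim that something is new, unique, unknown or untested is made for them only; others in the source may bear on it.

Three compounds share one core. Compound 1 `CCCCCc1ccc(NS(=O)(=O)c2ccc(N3CCNC3=O)cc2)cc1` gives 990 nM in a functional assay on HT-29 cells (Homo sapiens) for antiproliferative activity, read by sulforhodamine B assay, with a stated time of 48 h; a higher number here means a weaker inhibitor, a lower number a stronger inhibitor. Compound 2 `COc1ccc(NS(=O)(=O)c2ccc(N3CCNC3=O)cc2)cc1` gives 800 nM in this assay, and compound 3 `Cc1ccccc1NS(=O)(=O)c1ccc(N2CCNC2=O)cc1` gives 200 nM. Compound 2 stands second highest of the three numbers: the step of a 1.2-fold lower number from compound 1 to compound 2 (0.09 log units; within the scatter) lies within the scatter, while the step of a 4.0-fold lower number from compound 2 to compound 3 (0.60 log units; beyond the scatter) lies beyond it. Compound 4 `O=C1NCCN1c1ccc(S(=O)(=O)Nc2ccc(OC(F)F)cc2)cc1` differs from compound 2 by difluoromethyl in place of methyl on an oxygen on an aromatic ring. For the measured compounds named here, the only measured step that changes the group on that ring, from compound 1 to compound 2, stayed within the scatter; the step to compound 3 exchanges the whole 4-methoxyphenyl for 2-methylphenyl on the sulfonamide nitrogen and bears little here. Going by the values given here, no measured compound carries difluoromethyl. Compound 4 is therefore expected to show a step of a 1.1-fold lower number from compound 2 to compound 4 (0.06 log units; within the scatter), nothing beyond the scatter. Compound 4 is estimated at 700 nM, between 300 nM and 1600 nM.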

Compound 4, half-maximal inhibitory concentration: 650 nM
Compound 4: middle estimate off by 1.1-fold (0.03 log units), on the high side; the measured number falls inside the stated range.
By their numbers in this assay, from the lowest: compound 3; then compounds 4, 2 and 1 (each within the scatter of the next).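

In this assay, difluoromethyl in place of methyl on the oxygen gives a 1.2-fold lower number from compound 2 to compound 4 (0.09 log units; within the scatter), the first measured change within the methoxy group itself. Difluoromethoxy in place of pentyl gives a 1.5-fold lower number from compound 1 to compound 4 (0.18 log units; within the scatter), so pentyl, methoxy and difluoromethoxy on this aromatic carbon all stand within the scatter of one another. No measurement at hand offers an explanation for this result. As far as these compounds go, whether an amine or a carboxylic acid at this place would produce a step beyond the scatter remains open. So does the effect of difluoromethoxy on the 2-methylphenyl group of compound 3.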